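Pyrazole series: phenoxy to dimethylamino, cytotoxicity at one dose

The source may hold more compounds than are shown below. What is called first, only, known or untested is meant among the compounds shown, and "the series" means these compounds.

Measured compounds:
compound 1 `COc1cc(C)cc(-c2c(-c3ccnc(-c4ccc(C(C)=O)cc4)c3)cnn2CC#N)c1` 100%
compound 2 `COc1cc(C)cc(-c2nn(CC#N)cc2-c2ccc(-c3cccc(C(C)=O)c3)nc2)c1` 95%
compound 3 `Cc1cc(O)cc(-c2nn(CC#N)cc2-c2ccnc(-c3ccc(Oc4ccccc4)cc3)c2)c1` 95%

All three numbers come from a functional assay on NCI-H322M cells (Homo sapiens) for cytotoxicity, read by sulforhodamine B assay, with a stated time of 48 h, tested at 100 nM; a lower number here means a stronger effect, a higher number a weaker effect of the compound at the concentration tested. In this assay compound 3 gives 95%, level at the digits shown with compound 2, which gives 95%; together these are the lowest of the three numbers. Compound 1 gives 100%, a number five points higher than compound 3 and within the scatter, so nothing separates the three in this assay.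

The step under consideration leads from compound 3 to compound 4 `Cc1cc(O)cc(-c2nn(CC#N)cc2-c2ccnc(-c3ccc(N(C)C)cc3)c2)c1`. The change is dimethylamino in place of phenoxy on an aromatic carbon.

Among the compounds with values here, no step between two measured compounds is available in this assay, so the size of this change cannot be read from a precedent. Because compound 3 gives 95% and compound 1 gives 100%, numbers that sit close to one another, no step beyond the scatter is expected here. Compound 4 is expected to give about 96%, in the range 85% to 105%. The estimate implies a step of a number 1 percentage points higher from compound 3 to compound 4 (within the scatter), within the scatter.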

Compound 4, a percentage reported as activity, at one concentration (the size of the read-out at that concentration, not a potency): 93%
Compound 4: middle estimate off by 3 percentage points, on the high side; the measured number falls inside the stated range.
By their numbers in this assay, from the lowest: compounds 4, 2, 3 and 1 (each within the scatter of the next).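

In this assay, the first step read at this position runs a number 2 percentage points lower from compound 3 to compound 4 (within the scatter), with dimethylamino in place of phenoxy on the aromatic carbon para to a large group. The exchange removes the six-membered aromatic ring of the phenoxy group and takes the substituent from 7 heavy atoms to 3, yet the two compounds are not separated at this single concentration. No measurement at hand bears on why the two groups read alike.

As far as these compounds go, whether a carboxylic acid or a longer amine chain on this carbon would move the read-out beyond the scatter stays open. Also open, from the compounds shown here alone, is whether compound 3 and compound 4 would separate at another concentration, as a single-dose read-out gives no potency for either.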